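The source may hold more compounds than are shown below. What is called first, only, known or untested is meant among the compounds shown, and "the series" means these compounds.

Measured compounds:

Compound 1, `COc1ccc(/C=C(/F)c2cc(OC)c(OC)c(OC)c2)cc1O`: 100 nM
Compound 2, `COc1ccc(/C=C(/F)c2cc(OC)c(OC)c(OC)c2)cc1N`: 2.9 nM
Compound 3, `COc1ccc(/C(F)=C(/F)c2cc(OC)c(OC)c(OC)c2)cc1N`: 4.5 nM

All three were tested in a functional assay on HT-29 cells (Homo sapiens) for cytotoxicity, read by sulforhodamine B assay, with a stated time of 72 h; a lower number here means a stronger inhibitor, a higher number a weaker inhibitor. Compound 2 and compound 1 share one core and differ in a single spot: hydroxy in place of amino on an aromatic carbon. That one exchange made a large difference, a 34-fold higher number from compound 2 to compound 1 (1.54 log units; beyond the scatter), a step well beyond the usual scatter of such measurements. Compound 3 carries a different core, with compound 3 giving 4.5 nM in this assay; how its core differs from that of compound 2 is not broken down here. The values of compound 2 and compound 3 lie within the scatter of each other, so nothing can be said about which of the two is stronger, while compound 1 clearly gives a higher number than either.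

Compound 4, `COc1ccc(/C(F)=C(/F)c2cc(OC)c(OC)c(OC)c2)cc1O`, has not yet been measured. It stands to compound 3 as compound 1 stands to compound 2: hydroxy in place of amino on an aromatic carbon. The surroundings of the exchanged group, as described for both pairs, match word for word, so this is the same change on a different core. Compound 4 is expected to give about 150 nM in this assay. Its value is estimated to fall between 40 nM and 600 nM. The expected step is a 33-fold higher number from compound 3 to compound 4 (1.52 log units; beyond the scatter), because the same exchange once gave a 34-fold higher number from compound 2 to compound 1 (1.54 log units; beyond the scatter).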

Compound 4, half-maximal inhibitory concentration: 110 nM
Compound 4: the middle estimate sits 1.4-fold (0.13 log units) above what was measured; the range from low to high includes it.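

In this assay, putting hydroxy in place of amino on an aromatic carbon of the second core again produced a large step, a 24-fold higher number from compound 3 to compound 4 (1.39 log units; beyond the scatter), in the same direction as on the first core. Within the data shown here, the size of the step also carried over from one core to the other: the same change on two cores in this assay, a 34-fold higher number (1.54 log units; beyond the scatter) from compound 2 to compound 1 and a 24-fold higher number (1.39 log units; beyond the scatter) from compound 3 to compound 4, 1.4-fold (0.15 log units) apart, within the scatter of two such steps This shows that, for these two matched pairs, the exchange behaved alike on both cores, so the step seen on one core was a fair guide to the step on the other; it does not show that the same would hold on any further core or in other cells, and with only two pairs it says nothing about why the amino group gives the lower numbers.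

The compounds shown hold only amino and hydroxy at this place, so it remains open where a methylamino group, an amide, a methoxy group or a fluorine atom there would fall relative to these two. On these data alone, it also remains open whether the large step would persist on a core with a different substitution pattern on either aromatic ring.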